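The source may hold more compounds than are shown below. What is called first, only, known or untested is meant among the compounds shown, and "the series" means these compounds.

Measured compounds:
compound 1 `COc1ccc(N)c(C(=O)CCNC(=O)C2CCC2)c1` — in a functional assay for inhibition of kynurenine 3-monooxygenase (Rattus norvegicus), tested at 1 mM (a higher number here means more inhibition at the concentration tested (going by the name of the read-out), a lower number less inhibition), compound 1 gives 92.2%
compound 2 `CC(=O)NCCC(=O)c1cc(Cl)ccc1N` — in this assay compound 2 gives "not determined" (no result reported)

Among the measured compounds shown here, compound 1 stands alone here: its value is the only number in this assay, and compound 2 offers nothing to set against it. Compound 3 `CCCCC(=O)NCCC(=O)c1cc(OC)ccc1N` differs from compound 1 in one place: butyl in place of cyclobutyl on a carbonyl carbon. For the measured compounds named here, with no measured step to lean on, the step of a number 4.2 percentage points lower from compound 1 to compound 3 (within the scatter) is expected to stay within the usual scatter, neither up nor down. For compound 3 the estimated inhibition is 88%, with a range from 70% to 98%.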

Compound 3, a percentage reported as inhibition, at one concentration (the size of the read-out at that concentration, not a potency): 97.2%
Compound 3: middle estimate off by 9.2 percentage points, on the low side; the range from low to high includes it.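

The ring is not needed at this position: with butyl in place of cyclobutyl on a carbonyl carbon, this assay shows a number 5 percentage points higher from compound 1 to compound 3 (within the scatter). So an open chain and a four-membered ring of the same size cannot be told apart here. Nothing available explains this result.

Still open, from the compounds shown here alone, is whether a longer chain such as hexyl, a phenyl ring or an amine on that carbonyl carbon would do the same. A read-out at one concentration also leaves any potency difference between these two compounds unknown.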